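Chain extension at the chloroacetamide of compound 1

This account rests on a few compounds, and the source may have more. Where it says the series, first, only, none or still open, it means among the compounds named here.

Measured so far:
compound 1, `O=C(CCl)Nc1ccc(SCC(=O)Nc2cc(Cl)ccn2)cc1`: 2800 nM
compound 2, `O=C(CCl)Nc1ccc(SCC(=O)Nc2ccc(Cl)cc2)cc1`: > 80000 nM

Going by the values given here, in a functional assay on HeLa cells (Homo sapiens) for antiproliferative activity, read by MTT assay, with a stated time of 48 h (a higher number here means a weaker inhibitor, a lower number a stronger inhibitor), compound 1 gives 2800 nM, the only plain number in the set. For compound 2 the read-out is a limit of the assay, > 80000 nM, and not a number (the limit of > 80000 nM in this assay, at which 1 of the 2 values shown sits). The one step shown, an at least 28-fold higher number from compound 1 to compound 2 (1.45 log units; beyond the scatter), concerns the amide-type nitrogen at the other end of the shared core and is large.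

Compound 3, `O=C(CCCl)Nc1ccc(SCC(=O)Nc2cc(Cl)ccn2)cc1`, differs from compound 1 by chloromethyl in place of chloro on a saturated chain carbon bound to a carbonyl carbon. Among the compounds with values here, no measured step touches this part of the shared core; the step from compound 1 to compound 2 bears on a different place and gives no guide to the direction here. A step of uncertain direction in this assay is therefore expected, wider than the scatter is not excluded. Compound 3 is estimated at 8000 nM, within 2000 nM to 40000 nM, which means an expected step of a 2.9-fold higher number from compound 1 to compound 3 (0.46 log units; beyond the scatter).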

Compound 3, half-maximal inhibitory concentration: 21700 nM
Compound 3: middle estimate off by 2.7-fold (0.43 log units), on the low side; the measured number falls inside the stated range.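

In this assay, the chloroacetamide end of the shared core responds to chain extension: chloromethyl in place of chloro on a saturated chain carbon bound to a carbonyl carbon gives a 7.8-fold higher number from compound 1 to compound 3 (0.89 log units; beyond the scatter). This gives the first direction read at this position, a modest weakening in which compound 3 still gives a plain number and not a limit of the assay. Nothing measured on hand bears on the reason for this step.

Open, on these data alone, is what an amine or a plain methyl in place of the chlorine would give at this position. Also open, as far as these compounds go, are whether a longer chain, such as 3-chloropropyl on the carbonyl, would continue the same direction, and whether the step holds with 4-chlorophenyl on the amide-type nitrogen.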